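From E to Z at a Single Double Bond

The compounds below may be only part of what the source reports. "The series", "measured", "known", "first", "only" and "open" are said of these compounds alone.

Measured in a functional assay on MCF7 cells (Homo sapiens) for inhibition, read by sulforhodamine B assay, with a stated time of 48 h; a higher number here means a weaker inhibitor, a lower number a stronger inhibitor:
- compound 1 `CCNC(=O)Nc1ccc(/C=C\c2cc(OC)c(OC)c(OC)c2)cc1` gives 21000 nM
- compound 2 `COc1cc(/C=C/c2ccc(N3CCNC3=O)cc2)cc(OC)c1OC` gives 540 nM

Of these two, compound 2 at 540 nM has the lower number, and its gap to compound 1 lies beyond the usual scatter. Compound 3 `COc1cc(/C=C\c2ccc(N3CCNC3=O)cc2)cc(OC)c1OC` departs from it in one respect: the two compounds have the same atoms and bonds and differ only in configuration as drawn: 1 of 1 stereo elements differ; a double bond is drawn E in compound 2 and Z in compound 3. A double bond is drawn E in compound 2 and Z in compound 3. For the measured compounds named here, no measured pair here shows this kind of change, so any expectation is uncertain. A small move toward a lower number, within the scatter, is expected as a 1.8-fold lower number from compound 2 to compound 3 (0.26 log units; within the scatter). For compound 3 the estimated value is 300 nM, with an expected range from 30 nM to 4000 nM.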

Compound 3, half-maximal inhibitory concentration: 2.6 nM
Compound 3: middle estimate off by 120-fold (2.06 log units), on the high side; the whole stated range lies above it.
By their numbers in this assay, from the lowest: compound 3; then compound 2; then compound 1.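

In this assay, the configuration of the double bond alone accounts for a 210-fold lower number from compound 2 to compound 3 (2.32 log units; beyond the scatter), and the change can be placed there because of one fact: the fact that compounds 2 and 3 differ only in the configuration as drawn. With the Z double bond kept, 2-oxoimidazolidin-1-yl in place of (ethylcarbamoyl)amino on an aromatic carbon gives an 8100-fold lower number from compound 1 to compound 3 (3.91 log units; beyond the scatter), so this substituent also matters. The earlier compounds shown here differed in both places and could separate neither change. Going by these compounds, whether the Z configuration gives a similar gain with another group on that aromatic carbon, such as an amine or a carboxylic acid, remains open.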